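Compound 3 and a 3-bromophenyl addition

The source may report more compounds than this note shows. Statements on the series, on what has been measured and on what is new or still open speak of the compounds shown alone.

Measured in an ADME assay on HepG2 cells (Homo sapiens) for cytotoxicity, read by MTT assay, with a stated time of 48 h (on this read-out higher numbers stand for weaker inhibition and lower numbers for stronger inhibition), with every entry a limit and not a number:
compound 1 `O=S(=O)(c1ccc(-c2ccc3ncnc(Nc4ccccc4)c3c2)cc1)N1CCOCC1` gives > 3000 nM as a limit
compound 2 `Cc1ccc(Nc2ncnc3ccc(-c4ccc(S(=O)(=O)N5CCOCC5)cc4)cc23)cc1` gives > 15000 nM as a limit
compound 3 `COc1ccc(Nc2ncnc3ccc(-c4ccc(S(=O)(=O)N5CCOCC5)cc4)cc23)cc1Cl` gives > 15000 nM as a limit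

Compound 3 stands at the limit of > 15000 nM in this assay, at which 2 of the 3 values shown sit, and offers no exact starting number. The change to compound 4 `O=S(=O)(c1ccc(-c2ccc3ncnc(Nc4ccc(OCc5cccc(Br)c5)c(Cl)c4)c3c2)cc1)N1CCOCC1` is 3-bromophenyl in place of hydrogen on a saturated chain carbon bound to an oxygen on an aromatic ring and turns methoxy into (3-bromobenzyl)oxy. Among the compounds with values here, two measured steps bear on it, a step that the two limits leave unreadable from compound 1 to compound 3 and a step that the two limits leave unreadable from compound 2 to compound 3 and neither gives a size. No step beyond the scatter is therefore expected in this assay and no direction is expected either. The expected change is a number no higher from compound 3 to compound 4 (the limit leaves the size open) as a rough estimate. For compound 4 the estimated value is 15000 nM with an expected range from 4000 nM to 50000 nM and a report as a limit remains likely.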

Compound 4, half-maximal inhibitory concentration: > 15000 nM
Compound 4: no number, only a limit; the forecaster's own chance of this, stated with the estimate: 60%; the middle value lies on the limit itself.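

Within the data shown here, compound 3 and compound 4 are both reported only as limits in this assay, so no step between them can be read. The compounds shown leave open whether (3-bromobenzyl)oxy in place of methoxy shifts the read-out at all, and in which direction.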